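Halogen Pattern on the Phenyl Thioether of a Nucleoside

A few compounds are considered here, and "the series" means these few. Any claim that something is new, unique, unknown or untested is made for them only; others in the source may bear on it.

Three nucleoside analogues share one core and differ only in the group attached through sulfur. Compound 1 `OC[C@H]1O[C@@H](n2cnc3c(SC4CCCCC4)ncnc32)[C@H](O)[C@@H]1O` carries a cyclohexylsulfanyl group, and in an assay on isolated protein for binding affinity to Equilibrative nucleoside transporter 1 (Homo sapiens) (on this read-out higher numbers stand for weaker inhibition and lower numbers for stronger inhibition), compound 1 gives 6310 nM. Compound 2 `OC[C@H]1O[C@@H](n2cnc3c(CSc4ccccc4Br)ncnc32)[C@H](O)[C@@H]1O`, with a ((2-bromophenyl)sulfanyl)methyl group, gives 2400 nM in this assay, and compound 3 `OC[C@H]1O[C@@H](n2cnc3c(CSc4ccc(Cl)c(Cl)c4)ncnc32)[C@H](O)[C@@H]1O` gives 224 nM. The change a 2.6-fold lower number from compound 1 to compound 2 (0.42 log units; beyond the scatter) was modest, whereas an 11-fold lower number from compound 2 to compound 3 (1.03 log units; beyond the scatter) was large. Compound 3 therefore stands lowest of the three numbers, with compound 2 nearest and compound 1 furthest, both gaps beyond the scatter.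

Compound 4 `OC[C@H]1O[C@@H](n2cnc3c(CSc4cccc(Br)c4)ncnc32)[C@H](O)[C@@H]1O` differs from compound 3 in one place: 3-bromophenyl in place of 3,4-dichlorophenyl on a sulfur. The step that bears on this is an 11-fold lower number from compound 2 to compound 3 (1.03 log units; beyond the scatter), which shows that the halogen pattern on this phenyl ring can move the number a long way; the step from compound 1 to compound 2 speaks only to the aryl against cyclohexyl exchange. Compound 4 gives up one chlorine and replaces the other with bromine, so the number is expected to settle between those of compound 2 and compound 3. The expected step of a 2.7-fold higher number from compound 3 to compound 4 (0.43 log units; beyond the scatter) is a moderate weakening. Compound 4 is estimated to give 600 nM, with a range from 200 nM to 2000 nM.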

Compound 4, half-maximal inhibitory concentration: 363 nM
Beside the measured number, compound 4's estimate is 1.7-fold (0.22 log units) above it, and the stated range covers the measured number.
By their numbers in this assay, from the lowest: compounds 3 and 4 (each within the scatter of the next); then compound 2; then compound 1.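

The 3-bromophenyl group and the 3,4-dichlorophenyl group cannot be told apart in this assay, with a 1.6-fold higher number from compound 3 to compound 4 (0.21 log units; within the scatter) as the step, so on this sulfur a single bromine does as well as the two chlorines within the scatter. The earlier step to compound 3 changed the kind, number and place of the halogens all at once, whereas a 6.6-fold lower number from compound 2 to compound 4 (0.82 log units; beyond the scatter) is a change in which the ring keeps one bromine and only its place differs, 3-bromophenyl in place of 2-bromophenyl, and that alone moves the number beyond the scatter. The wider exchange, ((3-bromophenyl)sulfanyl)methyl in place of cyclohexylsulfanyl, now reads as a 17-fold lower number from compound 1 to compound 4 (1.24 log units; beyond the scatter) and is large, where the same exchange with the 2-bromophenyl ring was only modest.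

The data offer no measurement that explains why the place of the bromine matters. Still open, from the compounds shown here alone, is whether 3-chlorophenyl, 4-chlorophenyl or a ring bearing a methoxy group or an amine would hold the number at this level, and what a longer chain carrying the sulfur would do.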